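Para-substituent swap on the aryl oxadiazole semicarbazone series

This account rests on a few compounds, and the source may have more. Where it says the series, first, only, none or still open, it means among the compounds named here.

Compound 1 `C=C(C)[C@@H]1CC=C(C)/C(=N/NC(=O)Nc2nnc(-c3ccc(Cl)cc3)o2)C1` in a functional assay on the whole organism (strain Swiss albino) with Mus musculus as the target, with a stated time of 4 h (a lower number here means that less compound is needed, a higher number that more compound is needed for the effect), gives 300 mg/kg. Compound 2 `C=C(C)[C@@H]1CC=C(C)/C(=N/NC(=O)Nc2nnc(-c3ccc(F)cc3)o2)C1` in this assay gives 300 mg/kg, level with compound 1, and the step of no change at the digits printed from compound 1 to compound 2 (within the scatter) lies within the scatter. Compound 3 `C=C(C)[C@@H]1CC=C(C)/C(=N/NC(=O)Nc2nnc(-c3ccc(C)cc3)o2)C1` differs from compound 2 by methyl in place of fluoro on an aromatic carbon. Among the compounds with values here, the one measured step at this position, no change at the digits printed from compound 1 to compound 2 (within the scatter), is the only guide and shows no movement, so no step beyond the scatter is expected in this assay in either direction. Compound 3 is therefore estimated at 300 mg/kg, range 150 mg/kg to 600 mg/kg; the expected step is no change at the digits printed from compound 2 to compound 3 (within the scatter).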

Compound 3, minimum effective dose: 300 mg/kg
The estimate for compound 3 equals the measured number at the digits printed; the range from low to high includes it.
By their numbers in this assay, from the lowest: compounds 1, 2 and 3 (each within the scatter of the next).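

In this assay there is no change at the digits printed from compound 2 to compound 3 (within the scatter), and likewise no change at the digits printed from compound 1 to compound 3 (within the scatter). The position para to a large group on the aromatic ring therefore now reads the same with a carbon substituent, methyl, as with fluoro or chloro, so the flat reading is not confined to the two halogens among these three compounds. Nothing available explains this flat reading.

On these data alone, whether an amine, a carboxylic acid or a longer chain such as butyl at this position would shift the minimum effective dose remains open. So does the effect of any change away from this position on the shared core.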